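The compounds below may be only part of what the source reports. "The series", "measured", "known", "first", "only" and "open" are said of these compounds alone.

Measured compounds:
compound 1 `COc1ccc(OC)c(-c2cc(-c3ccc(C(=O)N(C)Cc4ccccc4)s3)on2)c1`: > 30000 nM
compound 2 `COc1ccc(OC)c(-c2cc(-c3ccc(C(=O)NCC4CC4)s3)on2)c1`: > 30000 nM
compound 3 `COc1ccc(OC)c(-c2cc(-c3ccc(C(=O)N4CCC(C(F)(F)F)CC4)s3)on2)c1`: > 30000 nM

In a functional assay on A549 cells (Homo sapiens) for cytotoxicity, read by XTT assay, with a stated time of 72 h (on this read-out higher numbers stand for weaker inhibition and lower numbers for stronger inhibition), compound 1 gives > 30000 nM, which is a limit of the assay and not a number. Compound 2 likewise returns only a limit, > 30000 nM. Compound 3 also stops at a limit, > 30000 nM. All three values sit at the limit of > 30000 nM in this assay, at which 3 of the 3 values shown sit, so the series cannot be ordered on this read-out. The steps a step that the two limits leave unreadable from compound 1 to compound 2, a step that the two limits leave unreadable from compound 1 to compound 3 and a step that the two limits leave unreadable from compound 2 to compound 3 each exchange the substituent on the carbonyl carbon, and none of them can be sized because both ends are limits.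

Compound 4 `CN(Cc1ccccc1)C(=O)c1ccc(-c2cc(C3=CC(=O)C=CC3=O)no2)s1` keeps the benzyl(methyl)amino amide of compound 1 and alters the other end of the shared core: a group of 8 heavy atoms (6 carbon, 2 oxygen; one six-membered non-aromatic ring of carbon only) in place of a group of 10 heavy atoms (8 carbon, 2 oxygen; one six-membered aromatic ring of carbon only), on an aromatic carbon. For the measured compounds named here, no measured step touches this position, and the three steps that exist are unreadable, so nothing in the data gives a direction or size for this change in this assay. The figure below is therefore an estimate with wide bounds rather than an extrapolation.

Compound 4 is expected in this assay to give about 10000 nM, somewhere between 1500 nM and 30000 nM. The step of an at least 3.0-fold lower number from compound 1 to compound 4 (0.47 log units; beyond the scatter) is the expected consequence, with a real chance that compound 4 again yields only a limit.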

Compound 4, half-maximal inhibitory concentration: > 30000 nM
Compound 4: a limit, no number; the forecaster's own chance of this, stated with the estimate: 40%; middle value at least 3.0-fold (0.47 log units) from the limit.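

Compound 4 returns > 30000 nM, a limit and not a number. The step from compound 1 to compound 4 cannot be read, because both ends are limits: the limit of > 30000 nM in this assay, at which 4 of the 4 values shown sit.

The compounds shown leave open whether any change to the amide or to the 2,5-dimethoxyphenyl position moves the read-out in this assay.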